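This account rests on a few compounds, and the source may have more. Where it says the series, first, only, none or still open, it means among the compounds named here.

Compound 1 `COc1ccc(-c2nnc(N3CCN(C(=O)CN4CCN(c5ccccc5)CC4)CC3)nc2-c2ccc(OC)cc2)cc1` — in an ADME assay on NIH3T3 cells (Mus musculus) for cytotoxicity, read by MTT assay, with a stated time of 24 h (a higher number here means a weaker inhibitor, a lower number a stronger inhibitor), compound 1 gives > 863000 nM, which is a limit of the assay.
Compound 2 `COc1ccc(-c2nnc(N3CCN(C(=O)CN4CCN(c5ccccc5OC)CC4)CC3)nc2-c2ccc(OC)cc2)cc1` — in this assay compound 2 gives > 821000 nM, which is a limit.
Compound 3 `COc1ccc(-c2nnc(N3CCN(C(=O)CN4CCN(c5cccc(Cl)c5)CC4)CC3)nc2-c2ccc(OC)cc2)cc1` — in this assay compound 3 gives > 814000 nM, which is a limit.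

Compound 3 therefore stands at a limit, and no number of its own is known. Every value shown is a limit (the limit of > 814000 nM in this assay, at which 1 of the 3 values shown sits, (the limit of > 821000 nM in this assay, at which 1 of the 3 values shown sits), (the limit of > 863000 nM in this assay, at which 1 of the 3 values shown sits)), so the three measured steps cannot be sized: a step that the two limits leave unreadable from compound 1 to compound 2, a step that the two limits leave unreadable from compound 1 to compound 3 and a step that the two limits leave unreadable from compound 2 to compound 3.

Compound 4 `COc1ccc(-c2nnc(N3CCN(C(=O)CN4CCN(c5ccc(OC)cc5)CC4)CC3)nc2-c2ccc(OC)cc2)cc1` differs from compound 3 in one place: 4-methoxyphenyl in place of 3-chlorophenyl on an amine nitrogen in a ring. The step from compound 2 to compound 3 bears most closely on this change, since it also exchanges the aryl group on that ring nitrogen, and the step from compound 1 to compound 2 adds a methoxy group on an aromatic carbon; both are unreadable between limits. Within the data shown here, no measured step gives a direction, so the step from compound 3 to compound 4 is expected to be a step that the limit leaves unreadable from compound 3 to compound 4, most likely again ending at a limit.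

Compound 4 is estimated to give 1500000 nM in this assay, within a range from 500000 nM to 5000000 nM.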

Compound 4, half-maximal inhibitory concentration: > 821000 nM
Compound 4 was reported as a limit; the forecaster's own chance of this, stated with the estimate: 85%; the middle value lies beyond the limit too.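

In this assay compound 4 gives > 821000 nM, which is a limit. The steps to compound 4 from compound 1, compound 2 and compound 3 therefore cannot be read, as each joins two limits. The compounds shown leave open whether exchanging the aryl group on the ring nitrogen changes the read-out at all.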